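Aryl amine swap on a shared pyrimidine-type core

The compounds below may be only part of what the source reports. "The series", "measured", "known", "first", "only" and "open" are said of these compounds alone.

Three compounds that share one core differ only in the aryl group on the amino nitrogen of that core. Compound 1 `Cc1cc(Nc2cc(N3CCN(C)CC3)nc(Nc3ccc(Cl)cc3)n2)n[nH]1` carries a 4-chlorophenyl there, compound 2 `Cc1cc(Nc2cc(N3CCN(C)CC3)nc(Nc3cccc([N+](=O)[O-])c3)n2)n[nH]1` a 3-nitrophenyl, and compound 3 `Cc1cc(Nc2cc(N3CCN(C)CC3)nc(Nc3ccc(C#N)cc3)n2)n[nH]1` a 4-cyanophenyl. In a functional assay on K562 cells (Homo sapiens) for antiproliferative activity, read by CCK-8 assay, with a stated time of 72 h (a higher number here means a weaker inhibitor, a lower number a stronger inhibitor), compound 1 gives 192 nM, compound 2 gives 138 nM, and compound 3 gives 58.1 nM. The step of a 1.4-fold lower number from compound 1 to compound 2 (0.14 log units; within the scatter) stays within the scatter, whereas a 3.3-fold lower number from compound 1 to compound 3 (0.52 log units; beyond the scatter) and a 2.4-fold lower number from compound 2 to compound 3 (0.38 log units; beyond the scatter) both lie beyond it, so compound 3 holds the lowest number of the three in this assay, with compound 2 nearest and compound 1 furthest.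

Compound 4 `COc1cccc(Nc2nc(Nc3cc(C)[nH]n3)cc(N3CCN(C)CC3)n2)c1` is the next member: 3-methoxyphenyl in place of 4-cyanophenyl on a nitrogen on an aromatic ring. Within the data shown here, none of the measured steps tests a methoxy group, so the only bearing is indirect. Both aryl groups without the cyano gave higher numbers than compound 3, as a 3.3-fold lower number from compound 1 to compound 3 (0.52 log units; beyond the scatter) and a 2.4-fold lower number from compound 2 to compound 3 (0.38 log units; beyond the scatter) show, and the move from one of them to the other, a 1.4-fold lower number from compound 1 to compound 2 (0.14 log units; within the scatter), stayed within the scatter. Compound 4 is therefore expected to land nearer to compounds 1 and 2 than to compound 3, a step of a 2.6-fold higher number from compound 3 to compound 4 (0.41 log units; beyond the scatter). In this assay compound 4 is estimated at 150 nM, between 60 nM and 400 nM.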

Compound 4, half-maximal inhibitory concentration: 509 nM
For compound 4 the middle estimate is 3.4-fold (0.53 log units) below the measured one, outside the stated range (above it).
By their numbers in this assay, from the lowest: compound 3; then compounds 2 and 1 (each within the scatter of the next); then compound 4.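

In this assay the aryl group on this nitrogen now gives a wider spread than the first three compounds showed, since compound 4 with its 3-methoxyphenyl holds the highest number of the four, with an 8.8-fold higher number from compound 3 to compound 4 (0.94 log units; beyond the scatter) and a 3.7-fold higher number from compound 2 to compound 4 (0.57 log units; beyond the scatter) and a 2.7-fold higher number from compound 1 to compound 4 (0.42 log units; beyond the scatter) all beyond the scatter. The comparison with compound 2 keeps the same numbered place on the phenyl ring and changes only the group, so the result depends on the group itself and not only on where it sits, while the 4-cyanophenyl and 3-methoxyphenyl groups match in their counts of heavy atoms, donors and acceptors, so those counts do not separate compound 3 from compound 4. No measurement at hand accounts for this difference.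

No pair shown carries one group in two places on the phenyl ring, so the share of the group and the share of its place in these differences stay unresolved. Also open, going by these compounds, is where an amine or a carboxylic acid on that phenyl ring would stand.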